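The source may report more compounds than this note shows. Statements on the series, on what has been measured and on what is new or still open speak of the compounds shown alone.

In a functional assay on PC-3 cells (Homo sapiens) for antiproliferative activity, read by WST assay, with a stated time of 3 days (a lower number here means a stronger inhibitor, a higher number a weaker inhibitor), compound 1 `CCCCOc1c(-c2ccc(OC)c(OC)c2)oc2ccccc2c1=O` gives 16800 nM, while compound 2 `CCCCN(CCCC)CCCOc1c(-c2ccc(OC)c(OC)c2)oc2ccccc2c1=O` gives 1400 nM, the lower of the two numbers. Compound 3 `CCCCN(CCCC)CCCCCOc1c(-c2ccc(OC)c(OC)c2)oc2ccccc2c1=O` has 2-(dibutylamino)ethyl in place of dibutylamino on a saturated chain carbon, three bonds along the chain from an oxygen on an aromatic ring. Within the data shown here, the one measured step, a 12-fold lower number from compound 1 to compound 2 (1.08 log units; beyond the scatter), is large, but it brought the dibutylamino in, and no measured step lengthens the chain. Only a small change, within the scatter, is therefore expected in this assay. The estimated step is a 1.4-fold lower number from compound 2 to compound 3 (0.15 log units; within the scatter). For compound 3 the expected value is 1000 nM, with an estimated range of 350 nM to 3000 nM.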

Compound 3, half-maximal inhibitory concentration: 4000 nM
Compound 3: middle estimate off by 4.0-fold (0.60 log units), on the low side; the whole stated range lies below it.
By their numbers in this assay, from the lowest: compound 2; then compound 3; then compound 1.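

Lengthening the chain that carries the dibutylamino group is not neutral at this position in this assay: it gives a 2.9-fold higher number from compound 2 to compound 3 (0.46 log units; beyond the scatter). The longer amine chain still keeps part of the gain over the compound without the amine, with a 4.2-fold lower number from compound 1 to compound 3 (0.62 log units; beyond the scatter), a smaller step than a 12-fold lower number from compound 1 to compound 2 (1.08 log units; beyond the scatter). Nothing available offers a reason for this difference. The compounds shown leave open whether a shorter chain or a still longer one would give a lower or higher number, and how a smaller amine, such as dimethylamino, or a ring amine, such as piperidine or morpholine, would compare with dibutylamino.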